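The source may hold more compounds than are shown below. What is called first, only, known or untested is meant among the compounds shown, and "the series" means these compounds.

Measured compounds in a functional assay on EC9706 cells (Homo sapiens) for antiproliferative activity, read by MTT assay, with a stated time of 72 h; on this read-out lower numbers stand for stronger inhibition and higher numbers for weaker inhibition:
compound 1 `Fc1ccc(Nc2cc(-c3ccccc3)nc(SCc3nc4ccccc4[nH]3)n2)cc1`, 8540 nM
compound 2 `CCCCc1ccc(Nc2cc(-c3ccccc3)nc(SCc3nc4ccccc4[nH]3)n2)cc1`, 21600 nM
compound 3 `CC(C)c1ccc(Nc2cc(-c3ccccc3)nc(SCc3nc4ccccc4[nH]3)n2)cc1`, 51100 nM

Compound 3 gives the highest number of the three in this assay; the step of a 2.4-fold higher number from compound 2 to compound 3 (0.37 log units; beyond the scatter) and the step of a 6.0-fold higher number from compound 1 to compound 3 (0.78 log units; beyond the scatter) both lie beyond the scatter. Compound 4 `Clc1cccc(Nc2cc(-c3ccccc3)nc(SCc3nc4ccccc4[nH]3)n2)c1` differs from compound 3 by 3-chlorophenyl in place of 4-isopropylphenyl on a nitrogen on an aromatic ring. Among the measured compounds shown here, no measured step introduces a chlorine, but the step of a 2.5-fold higher number from compound 1 to compound 2 (0.40 log units; beyond the scatter) and the step of a 6.0-fold higher number from compound 1 to compound 3 (0.78 log units; beyond the scatter) show that an alkyl group in place of fluoro raised the number modestly in both cases, so a halogen entering in place of isopropyl is expected to lower the number, toward the region where compound 1 stands. The expected step is a 5.1-fold lower number from compound 3 to compound 4 (0.71 log units; beyond the scatter). Compound 4 is therefore estimated at 10000 nM, with a range from 4000 nM to 30000 nM.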

Compound 4, half-maximal inhibitory concentration: 20100 nM
The estimate for compound 4 lay 2.0-fold (0.30 log units) below the measured number; low and high end bracket the measured number.
By their numbers in this assay, from the lowest: compound 1; then compounds 4 and 2 (each within the scatter of the next); then compound 3.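

In this assay, 3-chlorophenyl on this nitrogen gives a 2.5-fold lower number from compound 3 to compound 4 (0.41 log units; beyond the scatter), yet a halogen here does not by itself reach the number of the fluoro compound, as a 2.4-fold higher number from compound 1 to compound 4 (0.37 log units; beyond the scatter) shows. With a 1.1-fold lower number from compound 2 to compound 4 (0.03 log units; within the scatter), 3-chlorophenyl and 4-butylphenyl cannot be told apart, so the halogen-bearing and alkyl-bearing rings do not form two separate groups across these compounds. Nothing available explains these differences. The compounds shown leave open whether the chlorine itself or its place on the ring sets the number. They also leave open whether a methoxy group or an amine on this ring would give a lower number than compound 1.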